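Swapping the carbonyl cap for an ethylsulfonyl cap

A few compounds are considered here, and "the series" means these few. Any claim that something is new, unique, unknown or untested is made for them only; others in the source may bear on it.

Three compounds that share one core have been measured in a functional assay on CHO-K1 cells with Glucose-dependent insulinotropic receptor (Homo sapiens) as the target, read by a luciferase reporter, with a stated time of 5 h; a higher number here means a larger maximal response, a lower number a smaller maximal response:

Compound 1 `CC(C)(C)OC(=O)N1CCC(Oc2ncnc3c2CCN3c2ccc(S(C)(=O)=O)cc2F)CC1` gives 139%.
Compound 2 `CC(C)COC(=O)N1CCC(Oc2ncnc3c2CCN3c2ccc(S(C)(=O)=O)cc2F)CC1` gives 94%.
Compound 3 `CC(C)SC(=O)N1CCC(Oc2ncnc3c2CCN3c2ccc(S(C)(=O)=O)cc2F)CC1` gives 138%.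

Compound 3 stands second highest of the three. Its nearest neighbour is compound 1, with a number 1 percentage points lower from compound 1 to compound 3 (within the scatter), so the two are indistinguishable here. Its furthest is compound 2, with a number 44 percentage points higher from compound 2 to compound 3 (beyond the scatter).

Compound 4 `CCS(=O)(=O)N1CCC(Oc2ncnc3c2CCN3c2ccc(S(C)(=O)=O)cc2F)CC1` is the next step from compound 3. The change is ethylsulfonyl in place of (isopropylsulfanyl)carbonyl on an amine nitrogen in a ring. Within the data shown here, no measured step touches a sulfonyl, so the guidance is indirect. Changing only the alkyl part of the cap gave a number 45 percentage points lower from compound 1 to compound 2 (beyond the scatter), a large drop, whereas exchanging oxygen for sulfur in the cap gave a number 1 percentage points lower from compound 1 to compound 3 (within the scatter). The cap thus matters, and the new group departs from it more than either earlier change did. A fall of roughly the size seen for compound 2 is therefore expected, with wide uncertainty: the step is estimated as a number 38 percentage points lower from compound 3 to compound 4 (beyond the scatter). Compound 4 is expected to give about 100%, within 60% to 145%.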

Compound 4, largest response reached (reported as percent of maximum), in percent of the reference or control that the assay uses: 51%
The estimate for compound 4 lay 49 percentage points above the measured number; measured number outside the range, below it.
By their numbers in this assay, from the lowest: compound 4; then compound 2; then compounds 3 and 1 (each within the scatter of the next).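

The earlier compounds shown here changed only what sits on the carbonyl, whereas here the carbonyl goes too, and in this assay this gives a number 87 percentage points lower from compound 3 to compound 4 (beyond the scatter) for this single change. The same holds against the other carbonyl caps, with a number 88 percentage points lower from compound 1 to compound 4 (beyond the scatter) and a number 43 percentage points lower from compound 2 to compound 4 (beyond the scatter) in the same direction, so the ethylsulfonyl cap stands clear below all three. On this amine nitrogen, then, the type of cap can matter at least as much as its alkyl part, although ethylsulfonyl changes both at once and the two contributions cannot be separated here.

A tert-butylsulfonyl cap, which would pair the sulfonyl with the alkyl group of compound 1, or an acetyl cap, would help to separate them. No measurement shown here bears on why the maximal response falls.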